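A few compounds are considered here, and "the series" means these few. Any claim that something is new, unique, unknown or untested is made for them only; others in the source may bear on it.

Working notes on the series. Within the data shown here, compound 3 `Cc1nc(S(C)(=O)=O)ccc1Oc1ncnc(OC2CCN(C(=O)SC3CCC3)CC2)c1F` gives 77.4 nM in a functional assay on isolated protein for inhibition of Glucose-dependent insulinotropic receptor (Rattus norvegicus), read by HTRF and cAMP accumulation (on this read-out higher numbers stand for an effect only at larger amounts of compound and lower numbers for an effect already at smaller amounts), the lowest of the three numbers so far: compound 1 `Cc1nc(S(C)(=O)=O)ccc1Oc1ncnc(OC2CCN(C(=O)OC(C)F)CC2)c1F` gives 315 nM and compound 2 `Cc1nc(S(C)(=O)=O)ccc1Oc1ncnc(OC2CCN(C(=O)OC3COC3)CC2)c1F` gives 2500 nM. The steps of a 4.1-fold lower number from compound 1 to compound 3 (0.61 log units; beyond the scatter) and a 32-fold lower number from compound 2 to compound 3 (1.51 log units; beyond the scatter) both alter the group on the carbonyl carbon, and both lie beyond the scatter. Compound 4 `Cc1nc(S(C)(=O)=O)ccc1Oc1ncnc(OC2CCN(C(=S)OC3(C)CC3)CC2)c1F` differs from compound 3 in a group of 7 heavy atoms (5 carbon, 1 oxygen, 1 sulfur; one three-membered non-aromatic ring of carbon only) in place of a group of 7 heavy atoms (5 carbon, 1 oxygen, 1 sulfur; one four-membered non-aromatic ring of carbon only), on an amine nitrogen in a ring; the two have the same atoms, joined differently. Among the measured compounds shown here, no measured pair shows this rearrangement, so the two steps into compound 3 only show that this position moves the numbers. Since compound 3 holds the lowest number, a modest move toward higher numbers is expected, a 2.1-fold higher number from compound 3 to compound 4 (0.32 log units; beyond the scatter). The estimate for compound 4 is 160 nM, with a range from 40 nM to 650 nM.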

Compound 4, half-maximal effective concentration: 48.8 nM
Estimate against measurement, compound 4: 3.3-fold (0.52 log units) above; the range from low to high includes it.
By their numbers in this assay, from the lowest: compounds 4 and 3 (each within the scatter of the next); then compound 1; then compound 2.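

Rearranging the same atoms on the amine nitrogen in a ring, with a three-membered carbon ring replacing the four-membered one, gives a 1.6-fold lower number from compound 3 to compound 4 (0.20 log units; within the scatter) in this assay, so this position tolerates the rearrangement. Both sulfur-bearing groups stay well apart from the others, with a 51-fold lower number from compound 2 to compound 4 (1.71 log units; beyond the scatter) and a 6.5-fold lower number from compound 1 to compound 4 (0.81 log units; beyond the scatter). Nothing at hand explains these differences.

Ring size and atom connectivity change together here, so their separate contributions stay open. A plain cyclobutyl or 1-methylcyclopropyl carbamate, with oxygen in place of sulfur, or an amine on the carbonyl carbon, would test the role of sulfur.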